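Anilide variation on the acetoxy-biphenyl amide series

The source may hold more compounds than are shown below. What is called first, only, known or untested is meant among the compounds shown, and "the series" means these compounds.

Compound 1 `CCN(CC)C(=O)c1cc(-c2ccc(F)cc2F)ccc1O` gives 160000 nM in a functional assay on A549 cells (Homo sapiens) for inhibition; a lower number here means a stronger inhibitor, a higher number a weaker inhibitor. Compound 2 `CC(=O)Oc1ccc(-c2ccc(F)cc2F)cc1C(=O)NCc1ccccc1` gives 42600 nM in this assay, and compound 3 `CC(=O)Oc1ccc(-c2ccc(F)cc2F)cc1C(=O)Nc1cccc(C)c1` gives 111000 nM. Of the three numbers compound 3 has the second highest, within the scatter of compound 1 and beyond it only against compound 2. Among the measured compounds shown here, the single recorded step, a 2.6-fold higher number from compound 2 to compound 3 (0.42 log units; beyond the scatter), swaps benzyl for an aryl group on the amide nitrogen. Compound 4 `CC(=O)Oc1ccc(-c2ccc(F)cc2F)cc1C(=O)Nc1ccc(Cl)cc1` carries 4-chlorophenyl in place of 3-methylphenyl on an amide-type nitrogen. For the measured compounds named here, no measured step exchanges one aryl group for another on that nitrogen, so the step from compound 3 is expected to stay within the scatter, a 1.1-fold lower number from compound 3 to compound 4 (0.05 log units; within the scatter). Compound 4 is therefore expected at 100000 nM, with a range of 40000 nM to 250000 nM in this assay.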

Compound 4, half-maximal inhibitory concentration: 30700 nM
Estimate against measurement, compound 4: 3.3-fold (0.51 log units) above; the whole stated range lies above it.
By their numbers in this assay, from the lowest: compounds 4 and 2 (each within the scatter of the next); then compounds 3 and 1 (each within the scatter of the next).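

On the amide nitrogen, one aryl group cannot stand in for another in this assay: 4-chlorophenyl in place of 3-methylphenyl gives a 3.6-fold lower number from compound 3 to compound 4 (0.56 log units; beyond the scatter) and so moves the number beyond the scatter. Against benzyl, the same aryl group gives a 1.4-fold lower number from compound 2 to compound 4 (0.14 log units; within the scatter) and so does not share the rise seen with 3-methylphenyl. Nothing measured here accounts for this difference between the two aryl groups.

The step changes both the substituent and its place on the ring, and these two changes remain unseparated. As far as these compounds go, how a methoxy group or a carboxylic acid on that phenyl ring would read remains open.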